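The source may hold more compounds than are shown below. What is called first, only, known or untested is meant among the compounds shown, and "the series" means these compounds.

Measured so far in a functional assay on CCRF-CEM cells (Homo sapiens) for cytotoxicity; on this read-out higher numbers stand for lower toxicity in this test and lower numbers for higher toxicity in this test:
compound 1 `CCCC(=O)Nc1nc(N)nc2c1ncn2[C@H]1CO[C@@H](CO)O1` gives > 100000 nM as a limit
compound 2 `CCCCCC(=O)Nc1nc(N)nc2c1ncn2[C@H]1CO[C@@H](CO)O1` gives > 100000 nM as a limit
compound 3 `CCCCCCCCCC(=O)Nc1nc(N)nc2c1ncn2[C@H]1CO[C@@H](CO)O1` gives 65000 nM as a number

Compound 3 is the only one of the three with a true number. Compound 1 and compound 2 stay at the limit of > 100000 nM in this assay, at which 2 of the 3 values shown sit, and that is a limit, not a number.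

Compound 4 `CCCCCCCCCCCC(=O)Nc1nc(N)nc2c1ncn2[C@H]1CO[C@@H](CO)O1` differs from compound 3 by ethyl in place of hydrogen on a saturated chain carbon, nine bonds along the chain from a carbonyl carbon and so carries a longer chain on the shared core. Steps of the same kind bear on this change. The step of an at least 1.5-fold lower number from compound 2 to compound 3 (0.18 log units; that floor lies within the scatter) is the closest guide, and the step of an at least 1.5-fold lower number from compound 1 to compound 3 (0.18 log units; that floor lies within the scatter) has the same floor. Both floors lie within the scatter, so they show a direction only weakly. The step that the two limits leave unreadable from compound 1 to compound 2 gives no size at all.

Among these three compounds, none goes against a lower number with a longer chain, but the true size of the effect remains open. A further small drop is therefore expected, not clearly beyond the scatter. The expected step is a 1.9-fold lower number from compound 3 to compound 4 (0.27 log units; within the scatter) in this assay and it is only an estimate. For compound 4 the estimated value is 35000 nM with an expected range from 12000 nM to 90000 nM in this test.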

Compound 4, half-maximal cytotoxic concentration: 13000 nM
Compound 4: middle estimate off by 2.7-fold (0.43 log units), on the high side; the measured number falls inside the stated range.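

In this assay, among these compounds, ethyl in place of hydrogen on a saturated chain carbon, nine bonds along the chain from a carbonyl carbon, gives a 5.0-fold lower number from compound 3 to compound 4 (0.70 log units; beyond the scatter), and this is the first step with a true number at both ends and a size beyond the scatter. The steps from the two shorter chains, which earlier reached only floors within the scatter when taken to compound 3, now have floors beyond it: an at least 7.6-fold lower number from compound 2 to compound 4 (0.88 log units; beyond the scatter) and an at least 7.6-fold lower number from compound 1 to compound 4 (0.88 log units; beyond the scatter). Hexyl in place of hydrogen therefore reads differently at the two chain positions where it occurs: the same change on two cores in this assay, an at least 1.5-fold lower number (0.18 log units; that floor lies within the scatter) from compound 1 to compound 3 and an at least 7.6-fold lower number (0.88 log units; beyond the scatter) from compound 2 to compound 4; the limit leaves it open whether they differ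

On these data alone, how far compound 1 and compound 2 truly lie from the two longer chains stays unknown, since each of them gives only a limit: the limit of > 100000 nM in this assay, at which 2 of the 4 values shown sit. Whether a longer chain than that of compound 4 would lower the number further in this assay, or whether an amine or a carboxylic acid at the end of the chain would keep the step, stays open.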